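Amide nitrogen substituent: from compound 2 to compound 3

The compounds below may be only part of what the source reports. "The series", "measured", "known", "first", "only" and "open" are said of these compounds alone.

The series shares one core and varies the group on an amide-type nitrogen. Compound 1 `COc1ccc(CNC(=O)CN2C(=O)/C(=C/c3ccc(-c4ccc(Cl)cc4)o3)SC2=S)cc1` carries 4-methoxybenzyl there; in a functional assay on REH cells (Homo sapiens) for cytotoxicity, read by MTT assay, with a stated time of 72 h (on this read-out lower numbers stand for stronger inhibition and higher numbers for weaker inhibition), compound 1 gives 44000 nM. Compound 2 `O=C(CN1C(=O)/C(=C/c2ccc(-c3ccc(Cl)cc3)o2)SC1=S)Nc1nnn[nH]1` carries 1H-tetrazol-5-yl on the same nitrogen, and in this assay compound 2 gives 50000 nM. The step of a 1.1-fold higher number from compound 1 to compound 2 (0.06 log units; within the scatter) lies within the scatter. Going by the values given here, of the two numbers so far compound 2 shows the highest, yet its only neighbour, compound 1, sits within the scatter, so no order between the two can be read.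

Compound 3 `CCCCCCNC(=O)CN1C(=O)/C(=C/c2ccc(-c3ccc(Cl)cc3)o2)SC1=S` is the next case: hexyl in place of 1H-tetrazol-5-yl on an amide-type nitrogen. Among the compounds with values here, one measured step bears on changes at this nitrogen, the exchange of an aromatic group for another group there, a 1.1-fold higher number from compound 1 to compound 2 (0.06 log units; within the scatter), and it was flat. Nothing measured speaks to a hexyl chain at this position, so the expectation rests on that single flat step alone. For compound 3 the expected step is a 1.1-fold lower number from compound 2 to compound 3 (0.05 log units; within the scatter), within the scatter. Compound 3 is estimated at 45000 nM in this assay, with a range from 18000 nM to 110000 nM.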

Compound 3, half-maximal inhibitory concentration: 55000 nM
The estimate for compound 3 lay 1.2-fold (0.09 log units) below the measured number, and the stated range covers the measured number.
By their numbers in this assay, from the lowest: compounds 1, 2 and 3 (each within the scatter of the next).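

In this assay, hexyl on the amide-type nitrogen leaves the read-out flat against 1H-tetrazol-5-yl (a 1.1-fold higher number from compound 2 to compound 3 (0.04 log units; within the scatter)) and equally flat against 4-methoxybenzyl (a 1.3-fold higher number from compound 1 to compound 3 (0.10 log units; within the scatter)). Compound 1 and compound 2 both carry a ring on this nitrogen, whereas the hexyl group of compound 3 has no ring and 0 hydrogen-bond donors, so these three compounds show that neither the loss of the ring nor the loss of the tetrazole hydrogen-bond donor shifts the number beyond the scatter, and no order among them can be read. Nothing available explains this flat reading.

The compounds shown leave open whether any group on this nitrogen gives a number beyond the scatter of these three, for instance an aminoethyl group, a carboxylic acid on a short chain, or a dodecyl chain. They also leave open whether, with compound 3 at 55000 nM as the reference, changes on the shared core rather than on this nitrogen shift the number in this assay at all.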